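A few compounds are considered here, and "the series" means these few. Any claim that something is new, unique, unknown or untested is made for them only; others in the source may bear on it.

Measured in an ADME assay on RAW264.7 cells (Mus musculus) for cytotoxicity, read by MTT assay, with a stated time of 48 h (a higher number here means a weaker inhibitor, a lower number a stronger inhibitor), so far:
Compound 1 `Cc1cc(NC(=O)c2cccc(C(F)(F)F)c2)ccc1NS(C)(=O)=O` gives 110000 nM.
Compound 2 `Cc1cc(NC(=O)c2cc(C(F)(F)F)cc(C(F)(F)F)c2)ccc1NS(C)(=O)=O` reaches only a limit of the assay, > 250000 nM.
Compound 3 `Cc1cc(NC(=O)c2ccc(C#N)cc2)ccc1NS(=O)(=O)C(F)(F)F` gives 135000 nM.

Compound 1 has the lowest of the two numbers in this assay; compound 3 sits within the scatter of it, so no order between the two can be claimed. Compound 2 is a limit, as stated in the limit of > 250000 nM in this assay, at which 1 of the 3 values shown sits.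

Compound 4 `Cc1cc(NC(=O)c2cccc(C(F)(F)F)c2)ccc1NS(=O)(=O)C(F)(F)F` is not yet measured. It differs from compound 1 by trifluoromethyl in place of methyl on a sulfonyl sulfur. Within the data shown here, the only measured step, an at least 2.2-fold higher number from compound 1 to compound 2 (0.35 log units; beyond the scatter), concerns a trifluoromethyl entering on an aromatic carbon, not on the sulfonyl sulfur, so it bears on this change only loosely. Compound 3 carries the same (trifluoromethyl)sulfonyl group on a different amide and gives a number within the scatter of compound 1. In this assay compound 4 is therefore expected to show no step beyond the scatter, a 1.2-fold higher number from compound 1 to compound 4 (0.07 log units; within the scatter), with a risk that only a limit is reported. The estimate for compound 4 is 130000 nM, in the range 70000 nM to 250000 nM.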

Compound 4, half-maximal inhibitory concentration: 8720 nM
Compound 4: middle estimate off by 15-fold (1.17 log units), on the high side; measured number below the stated range.
By their numbers in this assay, from the lowest: compound 4; then compounds 1 and 3 (each within the scatter of the next). At a limit, above all of these: compound 2.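

In this assay, among these compounds, the sulfonyl sulfur is the first position where a single change moves the number strongly downward: trifluoromethyl in place of methyl there gives a 13-fold lower number from compound 1 to compound 4 (1.10 log units; beyond the scatter). Compound 3 carries the same (trifluoromethyl)sulfonyl group on a different amide and gives 135000 nM, so in the compounds shown this group does not bring a low number on its own, and the result depends on the amide partner as well. Nothing measured here accounts for the step.

Open, on these data alone, is whether a longer chain on the sulfonyl sulfur, such as ethyl, or an amine there keeps the lower number. Also open, as far as these compounds go, is how the (trifluoromethyl)sulfonyl group behaves on the amide of compound 2, whose own value is only a limit.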